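Biaryl Extension of a Quinolinone Carboxamide Series

The source may hold more compounds than are shown below. What is called first, only, known or untested is meant among the compounds shown, and "the series" means these compounds.

Measured compounds:
- compound 1, `O=C(Nc1ccc(Cl)cc1)c1ccnc2cc(Br)ccc12`: > 20000 nM
- compound 2, `O=C(Nc1ccc(OC(F)(F)F)cc1)c1cc(=O)[nH]c2cc(Br)ccc12`: > 20000 nM
- compound 3, `O=C(Nc1cccc(F)c1)c1cc(=O)[nH]c2cc(F)ccc12`: > 20000 nM

In a functional assay on KYSE-70 cells for antiproliferative activity against KYSE-70 cell line (Homo sapiens), read by MTT assay, with a stated time of 72 h (on this read-out higher numbers stand for weaker inhibition and lower numbers for stronger inhibition), compound 1 gives only a limit, > 20000 nM. Compound 2 likewise gives only a limit in this assay, > 20000 nM. Compound 3 also stands at a limit in this assay, > 20000 nM. Going by the values given here, no numbered value is available for any of the three, so no step between them can be measured; all that is known is the limit of > 20000 nM in this assay, at which 3 of the 3 values shown sit.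

Compound 4, `O=C(Nc1cccc(F)c1)c1cc(=O)[nH]c2cc(-c3ccc(F)c(CO)c3)ccc12`, is not yet measured. It differs from compound 3 in a single place: 4-fluoro-3-(hydroxymethyl)phenyl in place of fluoro on an aromatic carbon. Among the compounds with values here, since compound 3 sits at the limit, no step from a measured pair can guide the expectation, and the direction of any change can only be supposed. The account here expects that compound 4 will move into the measurable range, a step of an at least 4.0-fold lower number from compound 3 to compound 4 (0.60 log units; beyond the scatter), though with considerable uncertainty. Compound 4 is estimated at 5000 nM, with a range from 800 nM to 20000 nM.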

Compound 4, half-maximal inhibitory concentration: > 20000 nM
Compound 4: no number, only a limit (the forecaster's own chance of this, stated with the estimate: 40%); middle value at least 4.0-fold (0.60 log units) from the limit.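

Going by these compounds alone, compound 4 also gives only a limit in this assay (> 20000 nM), so no step from compound 3 to compound 4 can be read: the limit of > 20000 nM in this assay, at which 4 of the 4 values shown sit. The compounds shown leave open which change to the shared core, if any, would bring a measurable value in this assay.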